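The compounds below may be only part of what the source reports. "The series", "measured", "known", "first", "only" and "open" are said of these compounds alone.

Among the compounds with values here, in a physicochemical assay for lipophilicity (a higher number here means a more lipophilic compound, a lower number a more polar compound), compound 1 `COc1c(OC)c(OC(C)=O)c2c(Cl)cccc2c1OC(C)=O` gives 3.16, the lower of the two numbers available so far. Compound 2 `CCCOc1c(OCCC)c(OC(=O)C(C)C)c2cc(Cl)ccc2c1OC(=O)C(C)C` gives 7.5, a gap beyond the scatter from compound 1. Within the data shown here, no measured pair yet differs in only one place, so the data do not directly size any single change. Compound 3 `COc1c(OC)c(OC(C)=O)c2c(C)cccc2c1OC(C)=O` has not been measured in this assay. It keeps the core of compound 1 and differs in one place: methyl in place of chloro on an aromatic carbon. A small downward step is expected, not beyond the scatter. This expectation rests only on the structural change and on compound 1 at 3.16. The expected change is a number 0.11 log units lower from compound 1 to compound 3 (within the scatter). For compound 3 the estimated value is 3.05, with an expected range from 2.7 to 3.4.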

Compound 3, partition coefficient: 2.8
Compound 3: the middle estimate sits 0.25 log units above what was measured, and the stated range covers the measured number.
By their numbers in this assay, from the lowest: compound 3; then compound 1; then compound 2.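

In this assay, within the data shown here, the swap of methyl in place of chloro on an aromatic carbon gives a number 0.36 log units lower from compound 1 to compound 3 (beyond the scatter) and is the first single change that can be sized. At this position, ortho to a fused ring and meta to a fused ring, the read-out therefore responds to the swap, even though each group counts one heavy atom and neither brings a hydrogen-bond donor or acceptor. Nothing measured bears on the origin of this step.

As far as these compounds go, how an amine or a carboxylic acid at this position would read in this assay stays open. Also open, from the compounds shown here alone, is whether the same swap would give a step of similar size on compound 2, which differs from compound 1 in more than one place.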